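The source may report more compounds than this note shows. Statements on the series, on what has been measured and on what is new or still open speak of the compounds shown alone.

Compound 3 `COc1cc(-c2nnc(SCc3ccc(F)cc3F)o2)ccc1O` sits at the upper end of the three numbers in an ADME assay on cells (Mus musculus, strain BALB/c) for cytotoxicity, read by MTT assay, with a stated time of 24 h (on this read-out higher numbers stand for lower toxicity in this test and lower numbers for higher toxicity in this test), where compound 3 gives 520000 nM. Compound 2 `COc1cc(-c2nnc(SCc3ccc(Cl)cc3)o2)ccc1O` gives 480000 nM in this assay, and compound 1 `COc1cc(-c2nnc(SCc3cccc([N+](=O)[O-])c3)o2)ccc1O` gives 392000 nM; the gaps from compound 3 to both lie within the scatter, so none of the three can be set apart from the others on this read-out.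

Compound 4 `COc1cc(-c2nnc(SCc3cccc(Cl)c3)o2)ccc1O` differs from compound 3 in one place: 3-chlorophenyl in place of 2,4-difluorophenyl on a saturated chain carbon bound to a sulfur. Within the data shown here, the only measured step of the same kind is a 1.1-fold higher number from compound 2 to compound 3 (0.03 log units; within the scatter), an exchange of one halogen-bearing phenyl for another at the same place, and it stayed within the scatter. Compound 1, carrying 3-nitrophenyl at that place, also shows a value within the scatter of compound 3, so across the three compounds the group on the saturated chain carbon bound to a sulfur has not shifted the cytotoxicity number beyond the usual spread.

Compound 4 is therefore expected to give a number close to compound 3, with a step of a 1.1-fold lower number from compound 3 to compound 4 (0.03 log units; within the scatter) that means no change beyond the scatter. The estimate for compound 4 in this assay is 480000 nM, with a range from 300000 nM to 760000 nM.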

Compound 4, half-maximal cytotoxic concentration: 470000 nM
For compound 4 the middle estimate is 1.0-fold (0.01 log units) above the measured one; the range from low to high includes it.
By their numbers in this assay, from the lowest: compounds 1, 4, 2 and 3 (each within the scatter of the next).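

In this assay, among these compounds, the exchange of 4-chlorophenyl for 3-chlorophenyl on a saturated chain carbon bound to a sulfur is the only step here that keeps the same halogen and alters only the name of the phenyl group, and it gives a 1.0-fold lower number from compound 2 to compound 4 (0.01 log units; within the scatter), within the scatter. The direct exchange of chloro for nitro on an aromatic carbon gives a 1.2-fold higher number from compound 1 to compound 4 (0.08 log units; within the scatter), and the exchange of 2,4-difluorophenyl for 3-chlorophenyl gives a 1.1-fold lower number from compound 3 to compound 4 (0.04 log units; within the scatter), so all three new steps are within the scatter, and among these four compounds neither the kind of group on the phenyl nor the name of the phenyl group separates one number from another. No other measurement bears on this result, and nothing can be said about what lies behind it.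

From the compounds shown here alone, all four compounds keep the shared core and carry a halogen-bearing or nitro-bearing phenyl at this place, so it remains open whether changes to that core would shift the number. Going by these compounds, it also remains open whether an amine or a carboxylic acid on the phenyl, or a longer chain at this place, would take the number beyond the scatter.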